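The compounds below may be only part of what the source reports. "The series", "measured", "known", "first", "only" and "open" are said of these compounds alone.

Compound 1 `COc1ccccc1-c1ccc(CNC(=O)NC2CCN(Cc3ccc(C)cc3)CC2)cc1` gives 6.19 in an in vitro functional assay on HEK293 cells for antagonist activity at melanin-concentrating hormone receptor 1 (Homo sapiens), read by GTPgammaS binding, with a stated time of 45 min; on this read-out lower numbers stand for lower potency and higher numbers for higher potency (the scale is a negative logarithm). Compound 2 `Cc1ccc(CN2CCC(NC(=O)NCc3ccc(-c4cccc(C#N)c4)cc3)CC2)cc1` gives 6.39. Compound 3 `COc1ccccc1-c1ccc(CN(CC(=O)C(C)(C)O)C(=O)NC2CCN(Cc3ccc(C)cc3)CC2)cc1` gives 5.43.

Compound 4 `Cc1ccc(CN2CCC(NC(=O)N(CC(=O)C(C)(C)O)Cc3ccc(-c4cccc(C#N)c4)cc3)CC2)cc1` has not yet been measured. The change from compound 3 to compound 4 is 3-cyanophenyl in place of 2-methoxyphenyl on an aromatic carbon. The same change was made once before, from compound 1 to compound 2: 3-cyanophenyl in place of 2-methoxyphenyl on an aromatic carbon, and there it gave a number 0.20 log units higher from compound 1 to compound 2 (within the scatter). The core of compound 3 differs from the core of compound 1 by ((1-hydroxy-1-methylethyl)carbonyl)methyl in place of hydrogen on an amide-type nitrogen, a change that gave a number 0.76 log units lower from compound 1 to compound 3 (beyond the scatter). The place of the change is the same word for word in both pairs, so it is the same change on a different core. Compound 4 is expected to sit close to compound 3, since the earlier step of a number 0.20 log units higher from compound 1 to compound 2 (within the scatter) was small. The step for compound 4 is estimated at a number 0.20 log units higher from compound 3 to compound 4 (within the scatter). Compound 4 is estimated at 5.63, expected between 5.15 and 6.15.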

Compound 4, negative logarithm of the antagonist equilibrium constant: 5.3
The estimate for compound 4 lay 0.33 log units above the measured number; the range from low to high includes it.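

In this assay, putting 3-cyanophenyl in place of 2-methoxyphenyl gives a number 0.13 log units lower from compound 3 to compound 4 (within the scatter), so this change carries across both cores without a clear shift in the number: the same change on two cores in this assay, a number 0.20 log units higher (within the scatter) from compound 1 to compound 2 and a number 0.13 log units lower (within the scatter) from compound 3 to compound 4, 0.33 log units apart, within the scatter of two such steps. Adding the ((1-hydroxy-1-methylethyl)carbonyl)methyl group to the amide-type nitrogen gives a number 1.09 log units lower from compound 2 to compound 4 (beyond the scatter), which agrees with the earlier step on the other aryl group: the same change on two cores in this assay, a number 0.76 log units lower (beyond the scatter) from compound 1 to compound 3 and a number 1.09 log units lower (beyond the scatter) from compound 2 to compound 4, 0.33 log units apart, within the scatter of two such steps. These four compounds show that the two changes add up in this one set, but they do not show that the same would hold on any other core.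

Still open, on these data alone, is whether an amine or a carboxylic acid on that aromatic ring would shift the number on either core. Also open, as far as these compounds go, is whether a simple methyl on the amide-type nitrogen would lower the number as much as the larger group does.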